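Series notes: substitution on the five-membered ring nitrogen

The source may report more compounds than this note shows. Statements on the series, on what has been measured and on what is new or still open speak of the compounds shown alone.

Measured compounds:
compound 1 `C=CCCn1c(=O)c2[nH]cnc2n(CCC)c1=O` — 200 nM
compound 2 `CCCn1c(=O)n(CCC#N)c(=O)c2[nH]cnc21` — 1700 nM
compound 3 `CCCn1c(=O)n(C)c(=O)c2[nH]cnc21` — 1600 nM

In a functional assay (trachea) with Cavia porcellus as the target (on this read-out lower numbers stand for an effect already at smaller amounts and higher numbers for an effect only at larger amounts of compound), compound 3 stands second highest of the three numbers. Its nearest neighbour is compound 2: a 1.1-fold lower number from compound 2 to compound 3 (0.03 log units; within the scatter). Its furthest is compound 1: an 8.0-fold higher number from compound 1 to compound 3 (0.90 log units; beyond the scatter).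

Compound 4 `CCCn1c(=O)n(C)c(=O)c2c1ncn2CCOCC` is not yet measured. It differs from compound 3 in one place: 2-ethoxyethyl in place of hydrogen on an aromatic nitrogen.

Both measured steps into compound 3, an 8.0-fold higher number from compound 1 to compound 3 (0.90 log units; beyond the scatter) and a 1.1-fold lower number from compound 2 to compound 3 (0.03 log units; within the scatter), concern groups on the saturated chain carbons bound to the six-membered ring nitrogens of the shared core, as does an 8.5-fold higher number from compound 1 to compound 2 (0.93 log units; beyond the scatter). Among the compounds with values here, no measured step touches the five-membered ring nitrogen, so no step bears on this change directly. With nothing to anchor a direction, the expectation for compound 4 in this assay is a number close to that of compound 3, with a wide range to reflect the absence of a precedent; the expected step is a 1.1-fold lower number from compound 3 to compound 4 (0.03 log units; within the scatter). For compound 4 the estimate is 1500 nM, expected between 400 nM and 6000 nM.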

Compound 4, half-maximal effective concentration: 4600 nM
For compound 4 the middle estimate is 3.1-fold (0.49 log units) below the measured one; the measured number falls inside the stated range.
By their numbers in this assay, from the lowest: compound 1; then compounds 3 and 2 (each within the scatter of the next); then compound 4.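

In this assay, within the data shown here, the step of a 2.9-fold higher number from compound 3 to compound 4 (0.46 log units; beyond the scatter) is the first reading for the five-membered ring nitrogen, as all earlier steps concern saturated chain carbons. It gives this position a direction: with 2-ethoxyethyl in place of hydrogen on this aromatic nitrogen, the number rises beyond the scatter. The effect is still reached, so this nitrogen does not need its hydrogen for a measurable response in this series, though a larger amount of compound is required. No available evidence accounts for this step.

Going by these compounds, it remains open whether the rise follows from any group on this nitrogen, from the chain length or from the ether oxygen; a methyl group, a plain butyl chain or a 2-aminoethyl chain here would separate these readings. On these data alone, it is also open whether 2-ethoxyethyl has a similar effect on the core of compound 1.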